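This account rests on a few compounds, and the source may have more. Where it says the series, first, only, none or still open, it means among the compounds named here.

Measured so far:
- compound 1, `C=C1C(=O)O[C@@H]2CC(C)=C([C@@H](C)CCCOC(C)=O)[C@@H](OC(=O)CN3CCCCC3)[C@H]12`: 13900 nM in a functional assay on HCT-116 cells (Homo sapiens) for cytotoxicity, read by sulforhodamine B assay, with a stated time of 72 h; on this read-out lower numbers stand for stronger inhibition and higher numbers for weaker inhibition
- compound 2, `C=C1C(=O)O[C@@H]2CC(C)=C([C@@H](C)CCCOC(C)=O)[C@@H](OC(=O)COc3ccc(C(=O)OCCC)cc3)[C@H]12`: 37500 nM in this assay

Compound 1 holds the lowest number of the two measured compounds; compound 2 stands beyond the scatter from it, so compound 1 is the stronger of the pair on this read-out. Among the compounds with values here, no step between the two is computed here; the two values only show that the acyloxy group on the shared core is changed and the number moves.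

Compound 3, `C=C1C(=O)O[C@@H]2CC(C)=C([C@@H](C)CCCOC(C)=O)[C@@H](OC(=O)c3cccc(F)c3)[C@H]12`, is not yet measured. It differs from compound 1 in one place: 3-fluorophenyl in place of (piperidin-1-yl)methyl on a carbonyl carbon. The leaving group carries one hydrogen-bond acceptor, the entering one none; the entering group is a six-membered aromatic ring of carbon only in place of a six-membered non-aromatic ring with one hetero atom.

Within the data shown here, no step of this kind is known, so the size of the change is uncertain. The expected step of a 1.2-fold lower number from compound 1 to compound 3 (0.06 log units; within the scatter) is small, likely within the scatter, with no clear direction. Compound 3 is estimated at 12000 nM, with a range from 4000 nM to 36000 nM.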

Compound 3, half-maximal inhibitory concentration: 14500 nM
For compound 3 the middle estimate is 1.2-fold (0.08 log units) below the measured one, within the range that was stated.
By their numbers in this assay, from the lowest: compounds 1 and 3 (each within the scatter of the next); then compound 2.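

In this assay, 3-fluorophenyl in place of (piperidin-1-yl)methyl on a carbonyl carbon gives a 1.0-fold higher number from compound 1 to compound 3 (0.02 log units; within the scatter), so this read-out does not separate a six-membered aromatic ring of carbon only from a six-membered non-aromatic ring with one hetero atom at this position. The entering group carries no hydrogen-bond acceptor where the leaving group carries one, yet the step stays within the scatter, so in this pair the number does not follow that count or the change of ring type. Nothing measured on these compounds bears on why the two groups read alike.

A single pair leaves open whether this tolerance extends to other groups on the same carbonyl carbon, such as a carboxylic acid, a primary amine or a longer alkyl chain. Going by these compounds, the contribution of the fluorine also remains open, and a plain phenyl on the same carbonyl carbon would speak directly to it.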